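A few compounds are considered here, and "the series" means these few. Any claim that something is new, unique, unknown or untested is made for them only; others in the source may bear on it.

Values in a functional assay on MV4-11 cells (Homo sapiens) for inhibition, read by luminescence and CellTiter-Glo, with a stated time of 72 h; a higher number here means a weaker inhibitor, a lower number a stronger inhibitor:
- compound 1 `CCN1CCN(c2c(C(C)=O)c(=O)oc3cc(Nc4nccc(-c5ccc(F)cc5OC)n4)ccc23)CC1`: 740 nM
- compound 2 `COc1cc(F)ccc1-c1ccnc(Nc2ccc3c(N4CCCCC4)c(C(C)=O)c(=O)oc3c2)n1`: 730 nM
- compound 3 `COc1cc(F)ccc1-c1nc(Nc2ccc3c(N4CCN(C)CC4)c(C(C)=O)c(=O)oc3c2)ncc1Cl`: 1390 nM

Compound 3 gives the highest of the three numbers in this assay, but its gaps to compound 1 and to compound 2 both lie within the scatter, so no order among the three can be read from these values. Within the data shown here, the only step measured in one place, a 1.0-fold lower number from compound 1 to compound 2 (0.01 log units; within the scatter), concerns the amine on the shared core and leaves the chloro untouched, so no measured step bears on the change now at hand.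

Compound 4 `COc1cc(F)ccc1-c1ccnc(Nc2ccc3c(N4CCN(C)CC4)c(C(C)=O)c(=O)oc3c2)n1` differs from compound 3 by hydrogen in place of chloro on an aromatic carbon. Compound 1 and compound 2 also lack the chloro at that position and sit close to compound 3, so nothing in the series points to a step beyond the scatter. Compound 4 is therefore expected to land near the values of compound 1 and compound 2, with an estimated step of a 1.9-fold lower number from compound 3 to compound 4 (0.27 log units; within the scatter). The estimate for compound 4 in this assay is 750 nM, with a range from 350 nM to 1600 nM.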

Compound 4, half-maximal inhibitory concentration: 520 nM
The estimate for compound 4 lay 1.4-fold (0.16 log units) above the measured number, and the stated range covers the measured number.
By their numbers in this assay, from the lowest: compounds 4, 2, 1 and 3 (each within the scatter of the next, the first and the last beyond it).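

In this assay, among these compounds, the change at the carbon ortho to the 4-fluoro-2-methoxyphenyl group gives a 2.7-fold lower number from compound 3 to compound 4 (0.43 log units; beyond the scatter) and is the only step that lies beyond the scatter, so on this single pair hydrogen at this position gives the lower number than chloro. With hydrogen at that position, the amine shows no readable effect: a 1.4-fold lower number from compound 2 to compound 4 (0.15 log units; within the scatter) and a 1.4-fold lower number from compound 1 to compound 4 (0.15 log units; within the scatter) both lie within the scatter, so 4-methylpiperazin-1-yl, piperidin-1-yl and 4-ethylpiperazin-1-yl cannot be separated here. No measurement at hand accounts for the step from chloro to hydrogen.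

Going by these compounds, whether fluoro, methyl or a nitrile at this position would fall with hydrogen or with chloro stays open. Also open, on these data alone, is whether chloro gives a step of similar size with piperidin-1-yl or 4-ethylpiperazin-1-yl on the shared core.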